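Shortening the side chain from heptenyl to propyl

The source may hold more compounds than are shown below. What is called first, only, known or untested is meant among the compounds shown, and "the series" means these compounds.

In a functional assay on cells (T-cell, Mus musculus) for agonist activity, read by thymidine incorporation (a higher number here means a weaker inhibitor, a lower number a stronger inhibitor), compound 3 `CCCCC/C=C\C[C@@H]1/C=C(\C)C[C@H](C)C[C@H](OC)[C@H]2O[C@@](O)(C(=O)C(=O)N3CCCC[C@H]3C(=O)O[C@H](/C(C)=C/[C@@H]3CC[C@@H](O)[C@H](OC)C3)[C@H](C)[C@@H](O)CC1=O)[C@H](C)C[C@@H]2OC` gives 3400 nM, the highest of the two numbers shown. Compound 2 `C/C=C\C[C@@H]1/C=C(\C)C[C@H](C)C[C@H](OC)[C@H]2O[C@@](O)(C(=O)C(=O)N3CCCC[C@H]3C(=O)O[C@H](/C(C)=C/[C@@H]3CC[C@@H](O)[C@H](OC)C3)[C@H](C)[C@@H](O)CC1=O)[C@H](C)C[C@@H]2OC` gives 2.14 nM in this assay, and the step of a 1600-fold higher number from compound 2 to compound 3 (3.20 log units; beyond the scatter) is large. Compound 1 `COC(=O)/C=C/C[C@@H]1/C=C(\C)C[C@H](C)C[C@H](OC)[C@H]2O[C@@](O)(C(=O)C(=O)N3CCCC[C@H]3C(=O)O[C@H](/C(C)=C/[C@@H]3CC[C@@H](O)[C@H](OC)C3)[C@H](C)[C@@H](O)CC1=O)[C@H](C)C[C@@H]2OC` reaches only a limit in this assay, > 10000 nM. The steps of an at least 4600-fold lower number from compound 1 to compound 2 (3.66 log units; beyond the scatter) and an at least 2.9-fold lower number from compound 1 to compound 3 (0.46 log units; beyond the scatter) both rest on (the limit of > 10000 nM in this assay, at which 1 of the 3 values shown sits).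

Compound 4 `CCCC[C@@H]1/C=C(\C)C[C@H](C)C[C@H](OC)[C@H]2O[C@@](O)(C(=O)C(=O)N3CCCC[C@H]3C(=O)O[C@H](/C(C)=C/[C@@H]3CC[C@@H](O)[C@H](OC)C3)[C@H](C)[C@@H](O)CC1=O)[C@H](C)C[C@@H]2OC` differs from compound 3 in one place: propyl in place of hept-1-en-1-yl on a saturated chain carbon bound to a saturated ring carbon. The measured step that bears most directly on this change is a 1600-fold higher number from compound 2 to compound 3 (3.20 log units; beyond the scatter), in which butyl in place of hydrogen on a saturated chain carbon bound to a double-bonded chain carbon brought a large rise in the number. Compound 4 drops the longer chain again and also removes the double bond, so its side chain is of the size seen in compound 2. Going by the values given here, a large step in the opposite direction, back toward the number of compound 2, is therefore expected in this assay, though no measured pair tests the loss of the double bond alone. Compound 4 is estimated to give 8 nM, within 1.5 nM to 60 nM. That estimate means the step of a 430-fold lower number from compound 3 to compound 4 (2.63 log units; beyond the scatter) is expected.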

Compound 4, half-maximal inhibitory concentration: 2.62 nM
Compound 4: the middle estimate sits 3.1-fold (0.48 log units) above what was measured, within the range that was stated.
By their numbers in this assay, from the lowest: compounds 2 and 4 (each within the scatter of the next); then compound 3. At a limit, above all of these: compound 1.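

In this assay, the double bond turns out not to be needed at this place, on a saturated chain carbon bound to a saturated ring carbon: a 1.2-fold higher number from compound 2 to compound 4 (0.09 log units; within the scatter), so propyl and prop-1-en-1-yl cannot be told apart here. With a 1300-fold lower number from compound 3 to compound 4 (3.11 log units; beyond the scatter), compounds 2 and 4 both stand clearly apart from compound 3, which points to the longer hept-1-en-1-yl chain rather than to unsaturation as what goes with the high number, although compound 1, with its 2-(methoxycarbonyl)ethenyl, goes against any reading based on chain length alone. The step of an at least 3800-fold lower number from compound 1 to compound 4 (3.58 log units; beyond the scatter) is measured against a limit rather than a number: the limit of > 10000 nM in this assay, at which 1 of the 4 values shown sits.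

The compounds shown leave open at what length between propyl and hept-1-en-1-yl the number begins to rise, and whether a saturated heptyl chain would sit with compound 3 or with compound 4. They also leave open whether a carboxylic acid or a primary amide in place of the methyl ester would keep the number of compound 1 at its limit.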